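The source may hold more compounds than are shown below. What is called first, only, known or untested is meant among the compounds shown, and "the series" means these compounds.

Measured compounds in a functional assay on NCI-H23 cells (Homo sapiens) for inhibition, read by sulforhodamine B assay, with a stated time of 48 h; on this read-out higher numbers stand for weaker inhibition of growth and lower numbers for stronger inhibition of growth:
- compound 1 `O=C(Nc1cccc(-n2cc(-c3ccncc3)c(-c3ccc(Cl)c(O)c3)n2)c1)Nc1ccc(Cl)c(Cl)c1` gives 1220 nM
- compound 2 `COc1cc(-c2nn(-c3cccc(NC(=O)c4ccc(Cl)c(C(F)(F)F)c4)c3)cc2-c2ccncc2)ccc1Cl` gives 5390 nM
- compound 3 `O=C(Nc1cccc(-n2cc(-c3ccncc3)c(-c3ccc(Cl)c(O)c3)n2)c1)Nc1cc(C(F)(F)F)cc(C(F)(F)F)c1` gives 1020 nM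

Compound 2 has the highest number of the three in this assay, so it inhibits growth least: compound 1 and compound 3 both sit well below it, each gap lying beyond the usual scatter. Compound 4 `COc1cc(-c2nn(-c3cccc(NC(=O)Nc4cccc(C(F)(F)F)c4)c3)cc2-c2ccncc2)ccc1Cl` has not yet been measured. It differs from compound 2 at one place: (3-(trifluoromethyl)phenyl)amino in place of 4-chloro-3-(trifluoromethyl)phenyl on a carbonyl carbon. Going by the values given here, no measured pair shows this exact change, so the size of the step is uncertain. Still, compounds 1 and 3, which both carry an amino-linked outer ring on the carbonyl carbon as compound 4 will, give clearly lower numbers than compound 2, which suggests a move in the same direction. Compound 4 is therefore expected to give about 2200 nM in this assay, within a range from 700 nM to 7000 nM. That estimate means an expected step of a 2.5-fold lower number from compound 2 to compound 4 (0.39 log units; beyond the scatter), a modest improvement that may or may not exceed the scatter.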

Compound 4, concentration for 50% growth inhibition: 1180 nM
Beside the measured number, compound 4's estimate is 1.9-fold (0.27 log units) above it; measured number inside the range.
By their numbers in this assay, from the lowest: compounds 3, 4 and 1 (each within the scatter of the next); then compound 2.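

In this assay, going by these compounds alone, replacing 4-chloro-3-(trifluoromethyl)phenyl with (3-(trifluoromethyl)phenyl)amino on a carbonyl carbon gives a 4.6-fold lower number from compound 2 to compound 4 (0.66 log units; beyond the scatter), the first direct evidence that growth inhibition responds to a change at this place. The swap alters two things at once: the entering group brings a nitrogen with one hydrogen-bond donor, and the outer ring loses its chlorine. Nothing available here explains why the number falls.

This single step cannot show whether the added nitrogen, the lost chlorine or both account for the difference. A compound carrying (4-chloro-3-(trifluoromethyl)phenyl)amino on the same carbonyl carbon would separate the two parts, and an N-methylamino link would test whether the hydrogen on that nitrogen matters.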